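The compounds below may be only part of what the source reports. "The series", "measured", "known", "first", "only" and "open" are said of these compounds alone.

Series with a shared core, first seen as compound 1 `CC(C)c1ccc(-c2nc(SCc3cn(CC(=O)NC(=O)Nc4ccccn4)nn3)nc(Nc3ccccc3Cl)c2C#N)cc1`. In a functional assay on MGC-803 cells (Homo sapiens) for inhibition, read by MTT assay, with a stated time of 72 h (on this read-out higher numbers stand for weaker inhibition and lower numbers for stronger inhibition), compound 1 gives 19700 nM; the step of a 1.2-fold lower number from compound 1 to compound 2 (0.10 log units; within the scatter) leads to compound 2 `CC(C)c1ccc(-c2nc(SCc3cn(CC(=O)NC(=O)Nc4ccccn4)nn3)nc(Nc3ccccc3)c2C#N)cc1`, which in this assay gives 15800 nM, the lower of the two numbers, though not separated from compound 1 beyond the scatter. Compound 3 `COc1ccc(Nc2nc(SCc3cn(CC(=O)NC(=O)Nc4ccccn4)nn3)nc(-c3ccc(C(C)C)cc3)c2C#N)cc1` is not yet measured; it differs from compound 2 by methoxy in place of hydrogen on an aromatic carbon. Going by the values given here, the only step on that ring, a 1.2-fold lower number from compound 1 to compound 2 (0.10 log units; within the scatter), stayed within the scatter, so for compound 3 no step beyond the scatter is expected, giving a 1.1-fold lower number from compound 2 to compound 3 (0.05 log units; within the scatter) and an estimate of 14000 nM in this assay, within 6000 nM to 33000 nM.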

Compound 3, half-maximal inhibitory concentration: > 64000 nM
Compound 3: no number, only a limit; the forecaster's own chance of this, stated with the estimate: 10%; at least 4.5-fold (0.66 log units) between middle value and limit.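

Adding methoxy at this place on the anilino ring, para to a large group, gives the first step on that ring beyond the scatter in this assay (an at least 4.0-fold higher number from compound 2 to compound 3 (0.60 log units; beyond the scatter)), whereas the earlier step (a 1.2-fold lower number from compound 1 to compound 2 (0.10 log units; within the scatter)) stayed within it. The ring swap from 2-chlorophenyl to 4-methoxyphenyl also lies beyond the scatter (an at least 3.2-fold higher number from compound 1 to compound 3 (0.51 log units; beyond the scatter)). The true size of both steps remains unknown, since compound 3 gives only a limit: the limit of > 64000 nM in this assay, at which 1 of the 3 values shown sits.

Open, from the compounds shown here alone, is whether this step belongs to methoxy itself or to any group at this place, such as hydroxy, amino or chloro. Also open, going by these compounds, is whether 2-methoxyphenyl would keep the values of compound 1 and compound 2.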